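This account rests on a few compounds, and the source may have more. Where it says the series, first, only, none or still open, it means among the compounds named here.

Compound 1 `CCOC(=O)c1c(-c2cccc(F)c2)[nH]c2cc(OC)ccc2c1=O` gives > 22000 nM (a limit)
Compound 2 `CCOC(=O)c1c(-c2cccc(OC)c2)[nH]c2cc(OC)c(Cl)cc2c1=O` gives > 22000 nM (a limit)
Compound 3 `CCOC(=O)c1c(-c2cccc(F)c2)[nH]c2cc(OC)c(F)cc2c1=O` gives > 22000 nM (a limit)

All three compounds were tested in an ADME assay on HEK293 cells (Homo sapiens) for cytotoxicity, read by luminescence, with a stated time of 72 h (a lower number here means that less compound is needed, a higher number that more compound is needed for the effect), and none yields a number. Compound 3 therefore has no exact place in the series, and the set offers only the limit of > 22000 nM in this assay, at which 3 of the 3 values shown sit, as a reference point.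

Compound 4 `CCOC(=O)c1c(-c2cccc(Cc3nc(C)c(C)s3)c2)[nH]c2cc(OC)c(F)cc2c1=O` departs from compound 3 by this change: a group of 8 heavy atoms (6 carbon, 1 nitrogen, 1 sulfur; one five-membered aromatic ring with 2 hetero atoms) in place of one fluorine atom, on an aromatic carbon (on an aromatic carbon of a six-membered aromatic ring of carbon only, meta to a large group). Among the measured compounds shown here, the one measured step, a step that the two limits leave unreadable from compound 1 to compound 3 (fluoro in place of hydrogen on an aromatic carbon), has no readable size and is a different swap, so it gives no measure for this change.

With no size to carry over, no shift in either direction beyond the scatter is expected in this assay and compound 4 is expected to stay close to the limit. The estimated step is an at least 1.1-fold lower number from compound 3 to compound 4 (0.04 log units; that floor lies within the scatter) and it is only a rough expectation. For compound 4 the estimate is 20000 nM with an expected range from 7000 nM to 35000 nM as its span.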

Compound 4, half-maximal effective concentration: > 22000 nM
Compound 4 gave a limit, no number (the forecaster's own chance of this, stated with the estimate: 65%); middle value at least 1.1-fold (0.04 log units) away from the limit.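

Compound 3 and compound 4 both give only a limit in this assay, and the step between them cannot be read: the limit of > 22000 nM in this assay, at which 4 of the 4 values shown sit. The compounds shown leave open at what concentration any of them would reach the half-maximal effect.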